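A few compounds are considered here, and "the series" means these few. Any claim that something is new, unique, unknown or untested is made for them only; others in the source may bear on it.

Of the compounds shown here, three have been measured in an assay on cell membranes for binding affinity to Sigma non-opioid intracellular receptor 1 (Rattus norvegicus); a lower number here means a stronger inhibitor, a higher number a weaker inhibitor. Compound 1, `O=c1ccc2ccccc2n1CCCN1CCN(c2cccc(Cl)c2)CC1`, gives 620 nM. Compound 2, `O=c1ccc2ccc(O)cc2n1CCCN1CCN(c2ccc(F)cc2)CC1`, gives 1320 nM, and compound 3, `COc1cccc2c1CCC(=O)N2CCCN1CCN(c2cccc(C(F)(F)F)c2)CC1`, gives 490 nM. Among these three numbers, compound 1 stands second highest: its number and that of compound 3 sit close enough that repeated measurements could not tell them apart, while compound 2 shows a clearly higher number, meaning weaker binding, than compound 1.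

Compound 4, `COc1cccc2c1ccc(=O)n2CCCN1CCN(c2cccc(Cl)c2)CC1`, has not yet been measured in this assay. Its structure differs from compound 1 in one place: methoxy in place of hydrogen on an aromatic carbon, ortho to a fused ring and meta to a fused ring on the shared core. Going by the values given here, no measured pair in this set shows exactly this change, so the size of the step can only be guessed. Compound 3 carries a methoxy group on a related core and gives 490 nM, which suggests the change is unlikely to be large. The step from compound 1 to compound 4 is therefore expected to be a 1.2-fold lower number from compound 1 to compound 4 (0.09 log units; within the scatter), roughly within the scatter and, if anything, toward a lower number. Compound 4 is expected to give about 500 nM, with a plausible range from 200 nM to 1500 nM.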

Compound 4, half-maximal inhibitory concentration: 980 nM
Beside the measured number, compound 4's estimate is 2.0-fold (0.29 log units) below it; measured number inside the range.
By their numbers in this assay, from the lowest: compounds 3, 1, 4 and 2 (each within the scatter of the next, the first and the last beyond it).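

In this assay, going by these compounds alone, methoxy in place of hydrogen on an aromatic carbon of the shared core gives a 1.6-fold higher number from compound 1 to compound 4 (0.20 log units; within the scatter), the first direct reading of this change in the set. At this carbon, ortho to a fused ring and meta to a fused ring, the added methoxy therefore leaves a difference that repeated measurements could not distinguish from no change, something compound 3 could not show because it differs from compound 1 in more than one place. No measurement at hand offers an explanation for this result.

This single step leaves open whether a larger group on the same carbon, such as a butoxy chain, would also leave the number within the scatter. It also leaves open how an amine or a carboxylic acid would behave there, and whether methoxy on other carbons of the core would give a similar result.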